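This account rests on a few compounds, and the source may have more. Where it says the series, first, only, none or still open, it means among the compounds named here.

Measured so far in a physicochemical assay for solubility, at pH 6.8; a higher number here means a more soluble compound, a lower number a less soluble compound:
- Compound 1 `O=C(NCc1cccnc1)Nc1ccc(CNC(=O)c2ccc(CN3CCNCC3)cc2)cc1`: > 1000000 nM
- Compound 2 `C[C@H](NC(=O)CC(F)(F)F)c1ccc(NC(=O)[C@H]2C[C@@H]2c2cccnc2)cc1`: 41000 nM
- Compound 3 `C[C@H](NC(=O)C1CCOCC1)c1ccc(NC(=O)[C@H]2C[C@@H]2c2cccnc2)cc1`: 90000 nM

The value for compound 1 is a limit of the assay, not a number. That leaves two actual numbers, and compound 3 at 90000 nM holds the higher of them.

The next compound is compound 4 `C[C@H](NC(=O)[C@@H]1CCCN1C)c1ccc(NC(=O)[C@H]2C[C@@H]2c2cccnc2)cc1`. It keeps the core of compound 3 and changes one group on a carbonyl carbon: 1-methylpyrrolidin-2-yl in place of oxan-4-yl on a carbonyl carbon. A five-membered non-aromatic ring replaces a six-membered one, and the hetero atom in the ring is now nitrogen rather than oxygen.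

Among the compounds with values here, only one measured step was made at this same place: a 2.2-fold higher number from compound 2 to compound 3 (0.34 log units; beyond the scatter). It is a modest step, and it swapped a different pair of groups, so it guides the likely size only loosely. Within the data shown here, no measured pair tests the exchange of oxygen for nitrogen directly, which keeps the range wide.

A moderate rise in this assay is still expected, a little larger than that modest step. The expected change is a 3.3-fold higher number from compound 3 to compound 4 (0.52 log units; beyond the scatter).

For compound 4 the estimated value is 300000 nM, with an expected range from 90000 nM to 1000000 nM.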

Compound 4, solubility: 730000 nM
Beside the measured number, compound 4's estimate is 2.4-fold (0.39 log units) below it; the measured number falls inside the stated range.
By their numbers in this assay, from the lowest: compound 2; then compound 3; then compound 4. At a limit, above all of these: compound 1.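

At this place on a carbonyl carbon, this assay responds more strongly than the earlier pair showed: 1-methylpyrrolidin-2-yl in place of oxan-4-yl gives an 8.1-fold higher number from compound 3 to compound 4 (0.91 log units; beyond the scatter), a bigger move than a 2.2-fold higher number from compound 2 to compound 3 (0.34 log units; beyond the scatter). Set against 2,2,2-trifluoroethyl, the same group gives an 18-fold higher number from compound 2 to compound 4 (1.25 log units; beyond the scatter), so this single place spans a wide range of values while the rest of the molecule stays fixed. Oxan-4-yl and 1-methylpyrrolidin-2-yl have equal counts of heavy atoms, hydrogen-bond donors and hydrogen-bond acceptors, so those counts cannot explain the difference, whereas ring size, the ring hetero atom and the defined stereocentre all change at once.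

Which of those three changes carries the rise stays open, and groups such as 1-methylpiperidin-2-yl, oxolan-2-yl or the mirror-image form of 1-methylpyrrolidin-2-yl would help to pull them apart. How much further a rise could be read is also open, with compound 1 recorded at a limit of the assay rather than a number: the limit of > 1000000 nM in this assay, at which 1 of the 4 values shown sits.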